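The source may report more compounds than this note shows. Statements on the series, on what has been measured and on what is new or still open speak of the compounds shown alone.

In an ADME assay for permeability, using PAMPA (on this read-out higher numbers stand for higher permeability and lower numbers for lower permeability), compound 1 `O=C(Nc1ccc(F)cc1Cl)c1cc(Cl)ccc1O` gives 50.5 10^-6 cm/s, the higher of the two numbers available, while compound 2 `O=C(Nc1c(Cl)cc(F)cc1Cl)c1cc(Cl)ccc1O` gives 25 10^-6 cm/s. Compound 3 `O=C(Nc1ccc(Cl)cc1Cl)c1cc(Cl)ccc1O` has not yet been measured. It differs from compound 1 by chloro in place of fluoro on an aromatic carbon, with chloro in place of fluoro on an aromatic carbon. For the measured compounds named here, the only measured step that bears on this, a 2.0-fold lower number from compound 1 to compound 2 (0.31 log units; beyond the scatter), also brings in a chloro on an aromatic carbon and is modest, so a small fall or none beyond the scatter is expected in this assay. The expected step is a 1.3-fold lower number from compound 1 to compound 3 (0.12 log units; within the scatter). For compound 3 the estimate is 38 10^-6 cm/s, with an expected range of 19 10^-6 cm/s to 75 10^-6 cm/s.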

Compound 3, apparent permeability: < 22.4 10^-6 cm/s
Compound 3: no number, only a limit (the forecaster's own chance of this, stated with the estimate: 2%); middle value at least 1.6-fold (0.22 log units) away from the limit.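

At the place para to a large group, chloro in place of fluoro changes a single atom, yet in this assay it gives an at least 2.2-fold lower number from compound 1 to compound 3 (0.35 log units; beyond the scatter). For the compounds shown here, the earlier step involved a chloro added at another carbon, so this is the first sign that exchanging the fluoro itself also matters. For compound 3 the result is a limit, not a number: the limit of < 22.4 10^-6 cm/s in this assay, at which 1 of the 3 values shown sits.

As far as these compounds go, how far compound 3 really lies from compound 1 stays open. So does what a methyl, a methoxy or an amine would do in place of the fluoro.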